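A few compounds are considered here, and "the series" means these few. Any claim that something is new, unique, unknown or untested is made for them only; others in the source may bear on it.

Measured compounds:
- compound 1 `COc1ccc(Cn2cc(CNC(=O)c3cn(-c4ccccc4)nc3-c3ccccc3)nn2)cc1OC`: 10800 nM
- compound 2 `COc1cc(Cn2cc(CNC(=O)c3cn(-c4ccccc4)nc3-c3ccccc3)nn2)cc(OC)c1`: 12200 nM
- compound 3 `COc1ccc(Cn2cc(CNC(=O)c3cn(-c4ccccc4)nc3-c3ccc(F)cc3)nn2)cc1OC`: 200 nM

All three were run in a functional assay on HeLa cells (Homo sapiens) for antiproliferative activity, read by sulforhodamine B assay, with a stated time of 48 h; on this read-out higher numbers stand for weaker inhibition of growth and lower numbers for stronger inhibition of growth. Within the core of compound 1, the change 3,5-dimethoxyphenyl in place of 3,4-dimethoxyphenyl on a saturated chain carbon bound to an aromatic nitrogen gave a 1.1-fold higher number from compound 1 to compound 2 (0.05 log units; within the scatter), so the two values cannot be told apart. The core of compound 3 differs from that of compound 1 by fluoro in place of hydrogen on an aromatic carbon, a step of a 54-fold lower number from compound 1 to compound 3 (1.73 log units; beyond the scatter), which places compound 3 clearly apart from both others.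

Compound 4 `COc1cc(Cn2cc(CNC(=O)c3cn(-c4ccccc4)nc3-c3ccc(F)cc3)nn2)cc(OC)c1` is the unmeasured partner of compound 3, carrying (3,5-dimethoxyphenyl in place of 3,4-dimethoxyphenyl on a saturated chain carbon bound to an aromatic nitrogen). The place of this change is the same as in the pair compound 1 to compound 2, word for word, so this is the same change applied to the other core. For the measured compounds named here, the only guide to its size is the single step of a 1.1-fold higher number from compound 1 to compound 2 (0.05 log units; within the scatter), which was within the scatter; there is no second example to show whether the fluoro-bearing core responds differently. The step from compound 3 to compound 4 is therefore expected to be small, about a 1.2-fold higher number from compound 3 to compound 4 (0.06 log units; within the scatter), resting on that one pair and on compound 3 at 200 nM. Compound 4 is estimated at 230 nM, with a likely range of 100 nM to 550 nM.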

Compound 4, concentration for 50% growth inhibition: 360 nM
The estimate for compound 4 lay 1.6-fold (0.19 log units) below the measured number, and the stated range covers the measured number.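

In this assay, 3,5-dimethoxybenzyl in place of 3,4-dimethoxybenzyl on the fluoro-bearing core gave a 1.8-fold higher number from compound 3 to compound 4 (0.26 log units; within the scatter), so this change carried over from one core to the other with no measurable difference in step size: the same change on two cores in this assay, a 1.1-fold higher number (0.05 log units; within the scatter) from compound 1 to compound 2 and a 1.8-fold higher number (0.26 log units; within the scatter) from compound 3 to compound 4, 1.6-fold (0.20 log units) apart, within the scatter of two such steps Fluoro in place of hydrogen on an aromatic carbon gave a 34-fold lower number from compound 2 to compound 4 (1.53 log units; beyond the scatter), so the large gain in growth inhibition appears with either dimethoxybenzyl group: the same change on two cores in this assay, a 54-fold lower number (1.73 log units; beyond the scatter) from compound 1 to compound 3 and a 34-fold lower number (1.53 log units; beyond the scatter) from compound 2 to compound 4, 1.6-fold (0.20 log units) apart, within the scatter of two such steps Within these four compounds the two changes therefore behave independently, but each comparison rests on one pair per core, and this shows neither why fluoro has so large an effect nor that the independence extends to other groups.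

As far as these compounds go, it remains open whether chloro, methoxy or trifluoromethyl in place of the fluoro would give a step of similar size. From the compounds shown here alone, it is also open whether an unsubstituted benzyl or a longer chain bearing the dimethoxyphenyl group would stay as insensitive to change as the two dimethoxybenzyl groups.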